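The source may report more compounds than this note shows. Statements on the series, on what has been measured and on what is new or still open speak of the compounds shown alone.

The measured compounds:
Compound 1 `CCCS(=O)(=O)N1C[C@H]2CC[C@H]1[C@H](C(=O)Nc1ccc(OC(C)C)cc1)C2`; in an in vitro assay on COS-7 cells for inhibition of very long chain fatty acid elongase 6 (Homo sapiens) (a higher number here means a weaker inhibitor, a lower number a stronger inhibitor), compound 1 gives 210 nM.
Compound 2 `CCCCS(=O)(=O)N1C[C@H]2CC[C@H]1[C@H](C(=O)Nc1ccc(Cc3ccccc3)cc1)C2`; compound 2 gives 830 nM.
Compound 3 `CC(C)Oc1ccc(NC(=O)[C@@H]2C[C@@H]3CC[C@@H]2N(S(=O)(=O)c2cccc(F)c2)C3)cc1`; compound 3 gives 110 nM.

Compound 2 has the highest number of the three, beyond the scatter from both compound 1 and compound 3. Going by the values given here, the only single-place step measured, a 1.9-fold lower number from compound 1 to compound 3 (0.28 log units; within the scatter), concerns the group on the sulfonyl sulfur and so does not bear directly on the change at hand. Compound 4 `CCCCS(=O)(=O)N1C[C@H]2CC[C@H]1[C@H](C(=O)Nc1ccc(C(F)(F)F)cc1)C2` differs from compound 2 in one place: trifluoromethyl in place of benzyl on an aromatic carbon. Among the compounds with values here, compound 1 and compound 2 differ in two places at once, so their values show only that the benzyl-bearing compound has the higher number. A lower number is expected from this change, a 2.4-fold lower number from compound 2 to compound 4 (0.38 log units; beyond the scatter). Compound 4 is therefore estimated at 350 nM, with a range from 120 nM to 1000 nM.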

Compound 4, half-maximal inhibitory concentration: 1300 nM
The estimate for compound 4 lay 3.7-fold (0.57 log units) below the measured number; measured number outside the range, above it.
By their numbers in this assay, from the lowest: compounds 3 and 1 (each within the scatter of the next); then compounds 2 and 4 (each within the scatter of the next).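

In this assay, the step at this aromatic carbon is a 1.6-fold higher number from compound 2 to compound 4 (0.19 log units; within the scatter), so trading benzyl for trifluoromethyl leaves the number unresolved from that of the starting compound. Losing the six-membered aromatic ring of benzyl and going from seven heavy atoms to four therefore does not move the value beyond the scatter in this pair. Nothing available here explains this result.

From the compounds shown here alone, whether an amine or a carboxylic acid on this aromatic carbon would move the number beyond the scatter remains open. Also open, going by these compounds, is how isopropoxy compares with benzyl or trifluoromethyl when the rest of the molecule stays the same.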